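Piperidine methyl added to the N-methylated amide analogue

A few compounds are considered here, and "the series" means these few. Any claim that something is new, unique, unknown or untested is made for them only; others in the source may bear on it.

Measured compounds:
compound 1, `CC1CCN(c2ccc(Nc3ncc4c(n3)N(C3CCCC3)CC(=O)N4)cc2)CC1` — > 30000 nM
compound 2, `CN1C(=O)CN(C2CCCC2)c2nc(Nc3ccc(N4CCCCC4)cc3)ncc21` — 16900 nM

Among the measured compounds shown here, in a functional assay on HeLa cells (Homo sapiens) for inhibition, read by MTT assay, with a stated time of 48 h (a higher number here means a weaker inhibitor, a lower number a stronger inhibitor), compound 2 gives 16900 nM, the only number. Compound 1 is reported only as a limit, > 30000 nM. Compound 3, `CC1CCN(c2ccc(Nc3ncc4c(n3)N(C3CCCC3)CC(=O)N4C)cc2)CC1`, differs from compound 2 by methyl in place of hydrogen on a saturated ring carbon. For the measured compounds named here, no step between measured compounds bears on this change, so its size is unset; a shift within the scatter, or a small loss, is expected. Nearby sits (the limit of > 30000 nM in this assay, at which 1 of the 2 values shown sits). Compound 3 is estimated at 22000 nM, between 8000 nM and 60000 nM. The expected step is a 1.3-fold higher number from compound 2 to compound 3 (0.11 log units; within the scatter).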

Compound 3, half-maximal inhibitory concentration: > 30000 nM
Compound 3 ended at the assay's limit; the forecaster's own chance of this, stated with the estimate: 40%; at least 1.3-fold (0.13 log units) between middle value and limit.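

Methyl in place of hydrogen on a saturated ring carbon, piperidin-1-yl to 4-methylpiperidin-1-yl, now has a first reading in this assay, with an at least 1.7-fold higher number from compound 2 to compound 3 (0.24 log units; that floor lies within the scatter). Only a floor can be read, because compound 3 stands at a limit of the assay: the limit of > 30000 nM in this assay, at which 2 of the 3 values shown sit. The step for methyl on the amide-type nitrogen cannot be read, both ends being limits.

Still open, as far as these compounds go, is the true size of the piperidine methyl step, and whether a hydroxyl or a primary amine on this ring carbon would give a number in this assay rather than a limit.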